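A few compounds are considered here, and "the series" means these few. Any claim that something is new, unique, unknown or untested is made for them only; others in the source may bear on it.

Measured compounds in an assay on THP-1 cells for displacement of a labelled ligand from C-C chemokine receptor type 1 (Homo sapiens); a higher number here means a weaker inhibitor, a lower number a stronger inhibitor:
compound 1 `CC(C)[C@@H](NC(=O)c1cc2ccccc2s1)C(=O)N1CCC(c2ccc(Cl)cc2)CC1` — 58 nM
compound 2 `Cc1ccccc1C(=O)NC(C(=O)N1CCC(c2ccc(Cl)cc2)CC1)C(C)C` — 36 nM
compound 3 `CC[C@@H](C)[C@@H](NC(=O)CCc1ccccc1)C(=O)N1CCC(c2ccc(Cl)cc2)CC1` — 66 nM

In this assay compound 1 stands second highest of the three numbers, between compound 3 and compound 2; both neighbours lie within the scatter of it, so the three acyl groups on the shared core give no separation that can be read as a change.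

Compound 4 `CC(C)[C@@H](NC(=O)c1ccc(F)cc1)C(=O)N1CCC(c2ccc(Cl)cc2)CC1` is not yet measured. It differs from compound 1 in one place: 4-fluorophenyl in place of 1-benzothiophen-2-yl on a carbonyl carbon. Among the compounds with values here, no step between measured compounds covers this change. Given that the three acyl variants above sit within the scatter of one another, the step from compound 1 to compound 4 is expected to stay within the scatter as well, with no clear direction; the estimate is a 1.2-fold higher number from compound 1 to compound 4 (0.08 log units; within the scatter).

For compound 4 the expected value in this assay is 70 nM, with a range from 25 nM to 200 nM.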

Compound 4, half-maximal inhibitory concentration: 118 nM
Beside the measured number, compound 4's estimate is 1.7-fold (0.23 log units) below it; low and high end bracket the measured number.
By their numbers in this assay, from the lowest: compounds 2, 1, 3 and 4 (each within the scatter of the next, the first and the last beyond it).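

In this assay the aryl group on the carbonyl carbon gives its first readable step, with 4-fluorophenyl in place of 1-benzothiophen-2-yl producing a 2.0-fold higher number from compound 1 to compound 4 (0.31 log units; beyond the scatter), a modest weakening. The earlier compounds offered no single-place comparison, so this position is now shown to respond to this exchange. No measurement at hand explains the step. As far as these compounds go, whether the fluorine or the loss of the fused ring matters remains open. A plain phenyl or a 1-benzofuran-2-yl on this carbonyl carbon would separate the two.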